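This account rests on a few compounds, and the source may have more. Where it says the series, first, only, none or still open, it means among the compounds named here.

Working notes on the series. Compound 2 `C#Cc1ccc2nc(-c3ccc(NC(=O)Nc4cc(C(C)(C)C)on4)cc3)cn2c1` carries the shared core of compound 1 `CC(C)(C)c1cc(NC(=O)Nc2ccc(-c3cn4cc(I)ccc4n3)cc2)no1` with ethynyl on the aromatic carbon in place of the iodo of compound 1. For the measured compounds named here, in a functional assay on MV4-11 cells (Homo sapiens) for cytotoxicity, read by MTT assay, with a stated time of 72 h (a higher number here means a weaker inhibitor, a lower number a stronger inhibitor), compound 2 gives 8.62 nM, the lowest of the two numbers so far; the nearest is compound 1, which in this assay gives 98.6 nM. Going by the values given here, the single measured step, an 11-fold lower number from compound 1 to compound 2 (1.06 log units; beyond the scatter), concerns the same aromatic carbon and is large. Compound 3 `CC(C)(C)c1cc(NC(=O)Nc2ccc(-c3cn4cc(C5CC5)ccc4n3)cc2)no1` has not yet been measured in this assay. Its change from compound 2 is cyclopropyl in place of ethynyl on an aromatic carbon. Among the compounds with values here, the step from compound 1 to compound 2 shows that the group on this carbon can move the number a long way, but no measured pair compares cyclopropyl with ethynyl, so the direction for compound 3 is open; a moderate loss is taken as the more likely outcome, with a gain not excluded. The step expected is a 2.3-fold higher number from compound 2 to compound 3 (0.37 log units; beyond the scatter). For compound 3 the estimate in this assay is 20 nM, between 6 nM and 70 nM.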

Compound 3, half-maximal inhibitory concentration: 15.8 nM
Compound 3: middle estimate off by 1.3-fold (0.10 log units), on the high side; the measured number falls inside the stated range.
By their numbers in this assay, from the lowest: compounds 2 and 3 (each within the scatter of the next); then compound 1.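

In this assay the exchange of ethynyl for cyclopropyl on this aromatic carbon gives a 1.8-fold higher number from compound 2 to compound 3 (0.26 log units; within the scatter) and no separation of the two compounds, so a three-membered non-aromatic ring of carbon serves here as well as a triple bond outside aromatic rings. The other new step, a 6.2-fold lower number from compound 1 to compound 3 (0.80 log units; beyond the scatter) and beyond the scatter, shows that the distance from iodo seen earlier is not unique to ethynyl: two different all-carbon groups, each with no hydrogen-bond donors or acceptors, now stand apart from iodo at this position. Nothing measured alongside these numbers says what lies behind the difference from iodo.

As far as these compounds go, all three groups at this position are free of hydrogen-bond donors and acceptors, so it remains open whether an amine, a carboxylic acid or a longer chain such as n-butyl would hold the number at the level of compound 2 and compound 3 or lose it. Equally open, from the compounds shown here alone, is whether the match between ethynyl and cyclopropyl would persist in any read-out other than this one cell assay.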